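A Bromo-to-Methyl Swap in a Weakly Active Thiourea Pair

The source may hold more compounds than are shown below. What is called first, only, known or untested is meant among the compounds shown, and "the series" means these compounds.

Compound 1 `Cc1ccccc1NC(=S)N1CCc2c(sc(NC(=O)c3ccccc3C(F)(F)F)c2C(N)=O)C1` and compound 2 `Cc1ccccc1C(=O)Nc1sc2c(c1C(N)=O)CCN(C(=S)Nc1ccccc1Br)C2` share one core carrying a thiourea and a benzamide. In a functional assay on MKN-74 cells (Homo sapiens) for antiproliferative activity, with a stated time of 24 h (a lower number here means a stronger inhibitor, a higher number a weaker inhibitor), compound 1 gives 47400 nM. Compound 2 reaches only a limit of the assay in this assay, > 50000 nM, so no number is known for it. Compound 2 thus stands at the limit of > 50000 nM in this assay, at which 1 of the 2 values shown sits. Compound 3 `Cc1ccccc1NC(=S)N1CCc2c(sc(NC(=O)c3ccccc3C)c2C(N)=O)C1` differs from compound 2 by methyl in place of bromo on an aromatic carbon. Going by the values given here, no measured pair in this set traces that swap, so the expectation rests on both values shown being weak. The step from compound 2 to compound 3 is expected to be an at least 1.0-fold lower number from compound 2 to compound 3 (0.01 log units; that floor lies within the scatter), nothing beyond the scatter in either direction. Compound 3 is estimated at 48000 nM in this assay, within 18000 nM to 130000 nM, with a real chance that only a limit is reported again.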

Compound 3, half-maximal inhibitory concentration: > 50000 nM
Compound 3: no number, only a limit; the forecaster's own chance of this, stated with the estimate: 55%; middle value at least 1.0-fold (0.01 log units) away from the limit.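

With compound 2 and compound 3 both at a limit in this assay, the swap from 2-bromophenyl to 2-methylphenyl cannot be read, in either direction. Compound 3 also opens a second comparison, methyl in place of trifluoromethyl on an aromatic carbon, which gives an at least 1.0-fold higher number from compound 1 to compound 3 (0.02 log units; that floor lies within the scatter), so that swap is not shown to matter in this assay. Neither swap gives a compound with a clearly lower number, and most of the set now rests at the top of the measurable range: the limit of > 50000 nM in this assay, at which 2 of the 3 values shown sit.

From the compounds shown here alone, whether any group at these two places can bring the value clearly down stays open. How far compound 2 and compound 3 truly lie apart is also unknown, as is the effect of an amine, a carboxylic acid or a longer chain on either aromatic ring.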